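A few compounds are considered here, and "the series" means these few. Any claim that something is new, unique, unknown or untested is made for them only; others in the source may bear on it.

Working notes on the series.

Three compounds carry the shared core of compound 1 `Cc1cc2c(cc1C(=O)c1ccc(C(=O)OCCCCOC(=O)c3ccc(C(=O)Nc4ccc5c(c4)C(C)(C)CCC5(C)C)cc3)cc1)C(C)(C)CCC2(C)C`. In a functional assay on HL-60 cells (Homo sapiens) for inhibition, read by MTT assay, with a stated time of 48 h (on this read-out higher numbers stand for weaker inhibition and lower numbers for stronger inhibition), compound 1 gives 24700 nM. Compound 3 `C=C(c1ccc(C(=O)OCCOC(=O)c2ccc(C(=O)Nc3ccc4c(c3)C(C)(C)CCC4(C)C)cc2)cc1)c1cc2c(cc1C)C(C)(C)CCC2(C)C` gives 30700 nM in this assay. Compound 2 `CCCC(CCC)C(=O)OCCCCOC(=O)c1ccc(C(=O)Nc2ccc3c(c2)C(C)(C)CCC3(C)C)cc1`, which has no second copy of the bicyclic unit on the far end of the diester chain, stands highest of the three numbers in this assay with 914000 nM: compound 3 sits a long way lower, and compound 1 lower still, both gaps beyond the scatter.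

Compound 4 `CCCC(=O)OCCCOC(=O)c1ccc(C(=O)Nc2ccc3c(c2)C(C)(C)CCC3(C)C)cc1` is the unmeasured neighbour of compound 2. The change is (propylcarbonyl)oxy in place of (((1-propylbutyl)carbonyl)oxy)methyl on a saturated chain carbon, three bonds along the chain from an oxygen next to a carbonyl group. Among the compounds with values here, nothing measured among the three compounds isolates this kind of change, so no step between measured compounds can be quoted for it. Since the part of the molecule that separates compound 2 from compounds 1 and 3 is left untouched, the expectation is a step in this assay of about a 1.0-fold lower number from compound 2 to compound 4 (0.01 log units; within the scatter), that is, none beyond the scatter in either direction. Compound 4 is therefore estimated at 900000 nM, with a range from 300000 nM to 2500000 nM.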

Compound 4, half-maximal inhibitory concentration: 2990 nM
Compound 4: the middle estimate sits 300-fold (2.48 log units) above what was measured, outside the stated range (below it).
By their numbers in this assay, from the lowest: compound 4; then compounds 1 and 3 (each within the scatter of the next); then compound 2.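

In this assay, (propylcarbonyl)oxy in place of (((1-propylbutyl)carbonyl)oxy)methyl gives a 310-fold lower number from compound 2 to compound 4 (2.49 log units; beyond the scatter), so this saturated chain carbon, three bonds along the chain from an oxygen next to a carbonyl group, is a place where the read-out responds strongly to change. The group that leaves has 11 heavy atoms and the one that enters has 6, while the counts of oxygens, double bonds, hydrogen-bond donors and acceptors stay the same, so the difference lies in the carbons alone. No measurement at hand explains the step.

Compounds 2 and 4 differ in both the length of the chain and the group that ends it, so the two contributions cannot be separated. From the compounds shown here alone, how a straight longer acyl chain, a carboxylic acid or an amine at this chain end would read in this assay stays open.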